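The compounds below may be only part of what the source reports. "The series", "measured", "known", "first", "only" and "open" are said of these compounds alone.

Series notes. Going by the values given here, compound 1 `C#CCOc1ccc2oc(=O)ccc2c1` is the one member with a number: in a functional assay on A549 cells (Homo sapiens) for cytotoxicity, read by MTT assay, with a stated time of 48 h (on this read-out lower numbers stand for stronger inhibition and higher numbers for weaker inhibition), compound 1 gives 24000 nM. Compound 2 `O=c1ccc2cc(OCc3cc(-c4ccccc4)no3)ccc2o1` carries a phenyl on the five-membered ring; for compound 2 this assay reports "not determined" (no result reported). Compound 3 `O=c1ccc2cc(OCc3cc(-c4cccc(Cl)c4)no3)ccc2o1` likewise has "not determined" (no result reported) in this assay, so compound 3 stands without a value, alongside one further entry without a number. Compound 4 `N#Cc1ccccc1-c1cc(COc2ccc3oc(=O)ccc3c2)on1` differs from compound 3 by 2-cyanophenyl in place of 3-chlorophenyl on an aromatic carbon. Among the compounds with values here, no measured pair shows what this swap does; the only anchor is compound 1 with 24000 nM, so no step beyond the scatter is expected in either direction. Compound 4 is expected to give 20000 nM, with a range from 5000 nM to 80000 nM.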

Compound 4, half-maximal inhibitory concentration: 55800 nM
For compound 4 the middle estimate is 2.8-fold (0.45 log units) below the measured one, and the stated range covers the measured number.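

No step can be read between compound 3 and compound 4 in this assay. The compounds shown leave open what replacing 3-chlorophenyl with 2-cyanophenyl does to this read-out. No supporting data bear on the result.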